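This account rests on a few compounds, and the source may have more. Where it says the series, first, only, none or still open, it means among the compounds named here.

Three compounds on the shared core are measured in a functional assay on HeLa cells (Homo sapiens) for cytotoxicity, read by MTT assay, with a stated time of 48 h; a lower number here means a stronger inhibitor, a higher number a weaker inhibitor. Compound 1 `CCOC(=O)c1c(-c2c(Cl)c3ccccc3oc2=O)nn(-c2ccccc2)c1C(=O)OCC` gives 100000 nM. Compound 2 `CCOC(=O)c1c(-c2c(Cl)c3ccccc3oc2=O)nn(-c2ccc(OC)cc2)c1C(=O)OCC` gives 27000 nM. Compound 3 `CCOC(=O)c1c(-c2cc3ccccc3oc2=O)nn(-c2ccccc2)c1C(=O)OCC` gives 100000 nM. Compound 1 and compound 3 stand level at the digits printed, and together they hold the highest numbers of the three.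

The step from compound 1 to compound 2 is methoxy in place of hydrogen on an aromatic carbon, and it yields a 3.7-fold lower number from compound 1 to compound 2 (0.57 log units; beyond the scatter). The cores of compound 1 and compound 3 differ by hydrogen in place of chloro on an aromatic carbon, which gives no change at the digits printed from compound 1 to compound 3 (within the scatter).

Compound 4 `CCOC(=O)c1c(-c2cc3cc(OC)ccc3oc2=O)nn(-c2ccccc2)c1C(=O)OCC` is not yet measured. It differs from compound 3 by methoxy in place of hydrogen on an aromatic carbon. This is the same kind of change as that from compound 1 to compound 2, but not the same: in the earlier case the place is on a six-membered aromatic ring of carbon only, para to a large group, whereas here the ring is part of a fused or bridged system of two rings, meta to a fused ring and para to a fused ring.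

In this assay, within the data shown here, the step from compound 3 to compound 4 is expected to be a 1.7-fold lower number from compound 3 to compound 4 (0.22 log units; within the scatter), smaller than the earlier one, since the only precedent for compound 1 to compound 2 is a 3.7-fold lower number from compound 1 to compound 2 (0.57 log units; beyond the scatter) at a different place. Compound 4 is estimated at 60000 nM, likely between 25000 nM and 150000 nM.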

Compound 4, half-maximal inhibitory concentration: 145000 nM
For compound 4 the middle estimate is 2.4-fold (0.38 log units) below the measured one; the range from low to high includes it.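

In this assay, methoxy in place of hydrogen on an aromatic carbon gives a 1.5-fold higher number from compound 3 to compound 4 (0.16 log units; within the scatter), so the lowering of a 3.7-fold lower number from compound 1 to compound 2 (0.57 log units; beyond the scatter) does not recur here. Read as one change, methoxy does not carry a fixed step from one core to the other: the same change on two cores in this assay, a 3.7-fold lower number (0.57 log units; beyond the scatter) from compound 1 to compound 2 and a 1.5-fold higher number (0.16 log units; within the scatter) from compound 3 to compound 4, 5.4-fold (0.73 log units) apart, beyond the scatter of two such steps. This does not show that the core alone sets the outcome, as the two steps differ both in the place of the methoxy and in the chloro that compound 2 carries and compound 4 lacks, and each step rests on a single pair.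

Open, as far as these compounds go, is whether methoxy, at the place it holds in compound 2, gives a similar step on the core of compound 3, which would separate place from core. Also open, from the compounds shown here alone, is how this assay reads other groups, such as an amine at the place of the methoxy or a carboxylic acid in place of an ethyl ester.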